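Replacing the alkyne with a chlorophenyl ring on the core

The source may hold more compounds than are shown below. What is called first, only, known or untested is meant among the compounds shown, and "the series" means these compounds.

Compound 1 `CCCC#Cc1cc([C@@H]2O[C@H](CO)[C@@H](O)[C@H]2O)n2ncnc(N)c12` carries pent-1-yn-1-yl on the shared core, and in a functional assay on K562 cells (Homo sapiens) for antiproliferative activity, with a stated time of 72 h (on this read-out lower numbers stand for stronger inhibition and higher numbers for weaker inhibition), compound 1 gives 1100 nM. That is the only numbered result here; the other result is a limit of the assay. Compound 2 `Nc1ncnn2c([C@@H]3O[C@H](CO)[C@@H](O)[C@H]3O)cc(C#Cc3cccs3)c12` bears thiophen-2-yl in place of propyl on a triple-bonded carbon. In this assay compound 2 reaches only the limit > 100000 nM. That change is an at least 90-fold higher number from compound 1 to compound 2 (1.95 log units; beyond the scatter), and the result sits at the limit of > 100000 nM in this assay, at which 1 of the 2 values shown sits. Compound 3 `Nc1ncnn2c([C@@H]3O[C@H](CO)[C@@H](O)[C@H]3O)cc(-c3ccccc3Cl)c12` has not yet been measured; it differs from compound 1 by 2-chlorophenyl in place of pent-1-yn-1-yl on an aromatic carbon. Going by the values given here, only the step from compound 1 to compound 2 bears on this change, and it shows that placing an aromatic ring where propyl stood weakened inhibition very strongly. Compound 3 goes further, removing the triple bond altogether and attaching the ring directly to the core, so a large weakening in this assay is expected, a 27-fold higher number from compound 1 to compound 3 (1.44 log units; beyond the scatter). Compound 3 is therefore estimated at 30000 nM, within a range from 3000 nM to 100000 nM, with a real chance that only a limit is reported.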

Compound 3, half-maximal inhibitory concentration: > 100000 nM
Compound 3: no number, only a limit (the forecaster's own chance of this, stated with the estimate: 40%); middle value at least 3.3-fold (0.52 log units) away from the limit.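

In this assay, the loss seen with a ring on the triple bond also appears with a ring set directly on the core and no triple bond left: 2-chlorophenyl in place of pent-1-yn-1-yl gives an at least 90-fold higher number from compound 1 to compound 3 (1.95 log units; beyond the scatter), a step of the same printed size as the earlier one. Going by these compounds alone, compound 1, whose pent-1-yn-1-yl group has no ring, thus remains the only compound of the three with a readable number, and both ring-bearing groups end at the same limit of the assay: the limit of > 100000 nM in this assay, at which 2 of the 3 values shown sit. The step between compound 2 and compound 3 cannot be read, as both results are limits, so the two ways of attaching a ring cannot be ranked.

The compounds shown leave open how far the chain on the triple bond can change, for instance a shorter propyl-bearing alkyne, a longer chain, or a chain ending in an amine or a carboxylic acid. They also leave open whether a plain phenyl ring without the chlorine, or a saturated cyclohexyl ring, would give a number at this position.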